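A few compounds are considered here, and "the series" means these few. Any claim that something is new, unique, unknown or untested is made for them only; others in the source may bear on it.

The study measures serotonin N-acetyltransferase inhibition in an assay on isolated protein for inhibition of Serotonin N-acetyltransferase (Ovis aries), read by spectrophotometry, tested at 100 uM (on this read-out lower numbers stand for less inhibition and higher numbers for more inhibition at the one concentration tested (going by the name of the read-out)), across three compounds of two different build types. Compound 1 `O=C(O)CCCCCN1C(=O)C(C2C(=O)Nc3ccccc32)SC1=S`, which shares no core with the others, gives in this assay a read-out of 83%. Compound 2 `O=C(COc1ccc([N+](=O)[O-])cc1)N/N=C/c1ccccc1COc1ccccc1`, a hydrazone, gives in this assay only 11%. Compound 3 `O=C(O)COc1ccc(/C=N/NC(=O)c2ccc(OCc3ccccc3)cc2)cc1`, a second hydrazone carrying a benzyloxy group and a carboxymethoxy group, has in this assay no number but the entry "not determined" (no result reported): the result was not determined, so compound 3 stands nowhere on the scale shown by compound 1 and compound 2.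

Compound 4 `Cc1ccc(C)n1-c1ccc(C(=O)N/N=C/c2ccc(OCC(=O)O)cc2)cc1` keeps the hydrazone and the carboxymethoxy group of compound 3 and differs from it in one place: 2,5-dimethyl-1H-pyrrol-1-yl in place of benzyloxy on an aromatic carbon. Among the compounds with values here, since no measured step between compound 3 and compound 4 exists, the size of this step in this assay is unknown, and no direction beyond the scatter can be claimed. Taking the hydrazone compound 2 with its 11% as the nearest measured guide, compound 4 is expected in this assay to show around 22%, within a range of 2% to 55%.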

Compound 4, a percentage reported as inhibition, at one concentration (the size of the read-out at that concentration, not a potency): 92%
For compound 4 the middle estimate is 70 percentage points below the measured one; measured number outside the range, above it.
By their numbers in this assay, from the lowest: compound 2; then compounds 1 and 4 (each within the scatter of the next).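

No step can be read between compound 3 and compound 4, as compound 3 has no number to set against compound 4. The compounds shown leave open what replacing benzyloxy with 2,5-dimethyl-1H-pyrrol-1-yl does in this assay. No evidence bears on this result.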